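The compounds below may be only part of what the source reports. "The series", "measured", "known", "first", "only" and "open" are said of these compounds alone.

Three compounds share one core, differing only in the aryl group attached to it. Compound 1 `COc1cc(-n2cnc3ccc(-c4ccc(C)cc4F)cc32)cc(OC)c1OC` carries a 2-fluoro-4-methylphenyl group there. In a functional assay on A549 cells (Homo sapiens) for antiproliferative activity, read by MTT assay, with a stated time of 72 h (a lower number here means a stronger inhibitor, a higher number a weaker inhibitor), compound 1 gives only a limit, > 10000 nM, and not a measured number. Compound 2 `COc1ccc(-c2ccc3ncn(-c4cc(OC)c(OC)c(OC)c4)c3c2)cc1O` carries a 3-hydroxy-4-methoxyphenyl group in the same place, and in this assay compound 2 gives 200 nM. Compound 3 `COc1cc(-n2cnc3ccc(-c4cccc(C)c4C)cc32)cc(OC)c1OC` carries a 2,3-dimethylphenyl group, and compound 3 gives 9250 nM.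

Two measured steps start from compound 1. The first, an at least 50-fold lower number from compound 1 to compound 2 (1.69 log units; beyond the scatter), is a large gain; the second, an at least 1.0-fold lower number from compound 1 to compound 3 (0.03 log units; that floor lies within the scatter), is no gain that can be trusted, since compound 3 sits close to the limit at which compound 1 stands (the limit of > 10000 nM in this assay, at which 1 of the 3 values shown sits). Compound 4 `COc1cc(-n2cnc3ccc(-c4cccc(N)c4)cc32)cc(OC)c1OC` is the next step from compound 1: 3-aminophenyl in place of 2-fluoro-4-methylphenyl on an aromatic carbon. The group that enters brings one hydrogen-bond donor and one acceptor, as the group entering in compound 2 did, while the group entering in compound 3 brought neither. Compound 4 is therefore expected to show a clear gain, an at least 6.6-fold lower number from compound 1 to compound 4 (0.82 log units; beyond the scatter), though smaller than compound 2 reached. The estimate for compound 4 is 1500 nM, within a range from 300 nM to 8000 nM.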

Compound 4, half-maximal inhibitory concentration: 640 nM
Compound 4: the middle estimate sits 2.3-fold (0.37 log units) above what was measured; the measured number falls inside the stated range.
By their numbers in this assay, from the lowest: compound 2; then compound 4; then compound 3. At a limit, above all of these: compound 1.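

With 3-aminophenyl, a second group carrying a hydrogen-bond donor and acceptor now gives a large gain at this position in this assay (an at least 15-fold lower number from compound 1 to compound 4 (1.19 log units; beyond the scatter)) and also against the dimethylated group (a 14-fold lower number from compound 3 to compound 4 (1.16 log units; beyond the scatter)), so the strong result of compound 2 is no longer a lone case: among these four compounds, the two with such a group have the lower numbers, and none goes against that pattern. Having such a group does not settle the outcome, however, since the two groups that have one still differ by a modest step beyond the scatter (a 3.2-fold higher number from compound 2 to compound 4 (0.51 log units; beyond the scatter)). The first of these gains is only a floor, as compound 1 stands at a limit and not at a measured number: the limit of > 10000 nM in this assay, at which 1 of the 4 values shown sits.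

The compounds shown leave open whether the gain depends on the donor itself, which a 3-methoxyphenyl or 3-(dimethylamino)phenyl group in the same place would help to test. They also leave open what sets compound 2 apart from compound 4, a question that a 3-hydroxyphenyl group, without the methoxy of compound 2, could begin to answer.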